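Ring-halogen swaps on the oxamide anilide: tolerability

A few compounds are considered here, and "the series" means these few. Any claim that something is new, unique, unknown or untested is made for them only; others in the source may bear on it.

Compound 1, `Cc1nc(C(NC(=O)C(=O)Nc2ccc(Cl)cc2)C2CCCCN2)sc1CO`: in an ADME assay on TZM-b1 cells (Homo sapiens) for cytotoxicity, read by XTT assay, with a stated time of 3 days (a higher number here means that more compound is tolerated, a lower number that less compound is tolerated), compound 1 gives > 22000 nM, which is a limit of the assay and not a number.
Compound 2, `Cc1nc(C(NC(=O)C(=O)Nc2ccc(F)c(Cl)c2)C2CCCCN2)sc1CO`: in this assay compound 2 gives > 77800 nM, likewise a limit of the assay.
Compound 3, `Cc1ccc(NC(=O)C(=O)NC(c2nc(C)c(CO)s2)C2CCCCN2)c(F)c1`: in this assay compound 3 gives > 88000 nM, again only a limit.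

Compound 3 therefore stands at a limit, as do the other two, and no order among the three can be read. The observer notes that a step that the two limits leave unreadable from compound 1 to compound 2, a step that the two limits leave unreadable from compound 1 to compound 3 and a step that the two limits leave unreadable from compound 2 to compound 3 remain unreadable because the three values sit at the limit of > 22000 nM in this assay, at which 1 of the 3 values shown sits, the limit of > 77800 nM in this assay, at which 1 of the 3 values shown sits, and (the limit of > 88000 nM in this assay, at which 1 of the 3 values shown sits).

Compound 4, `Cc1nc(C(NC(=O)C(=O)Nc2ccc(Cl)c(F)c2)C2CCCCN2)sc1CO`, differs from compound 3 by 4-chloro-3-fluorophenyl in place of 2-fluoro-4-methylphenyl on an amide-type nitrogen. Going by the values given here, the three unreadable aryl swaps are the only steps that bear on this change, so in this assay no step beyond the scatter is expected, and the estimated step is an at least 1.1-fold lower number from compound 3 to compound 4 (0.04 log units; that floor lies within the scatter). Compound 4 is expected to give 80000 nM, in a range from 22000 nM to 250000 nM, most probably reported again only as a limit.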

Compound 4, half-maximal cytotoxic concentration: 58400 nM
Compound 4: the middle estimate sits 1.4-fold (0.14 log units) above what was measured; the measured number falls inside the stated range.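

Compound 4, carrying 4-chloro-3-fluorophenyl on the amide-type nitrogen, is the only one of the four shown that gives a number rather than a limit in this assay. This change of aryl group therefore yields two readable steps, an at least 1.5-fold lower number from compound 3 to compound 4 (0.17 log units; that floor lies within the scatter) and an at least 1.3-fold lower number from compound 2 to compound 4 (0.12 log units; that floor lies within the scatter), but each floor lies within the usual scatter, so neither establishes a real difference in tolerability. The step from compound 1, fluoro in place of hydrogen on an aromatic carbon, cannot be read because compound 1 stands at a limit: the limit of > 22000 nM in this assay, at which 1 of the 4 values shown sits.

From the compounds shown here alone, how far the true values of compound 2 and compound 3 lie from their limits remains open. Also open, going by these compounds, is whether a methoxy group or a nitrile on the same aryl ring would give a number in this assay.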